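A few compounds are considered here, and "the series" means these few. Any claim that something is new, unique, unknown or untested is made for them only; others in the source may bear on it.

Three compounds have been measured in a functional assay on KB cells (Homo sapiens) for antiproliferative activity, read by MTT assay, with a stated time of 72 h; a higher number here means a weaker inhibitor, a lower number a stronger inhibitor:

Compound 1 `COc1ccc(-c2sc(C(=O)O)cc2-c2cc(OC)c(OC)c(OC)c2)cc1`: 10400 nM
Compound 2 `COc1ccc(-c2sc(C(=O)O)cc2-c2cc(OC)c(OC)c(OC)c2)cc1[N+](=O)[O-]`: 35900 nM
Compound 3 `COc1ccc(-c2ccsc2-c2cc(OC)c(OC)c(OC)c2)cc1`: 7400 nM

Compound 2 differs from compound 1 by nitro in place of hydrogen on an aromatic carbon. In this assay this gave a 3.5-fold higher number from compound 1 to compound 2 (0.54 log units; beyond the scatter). Compound 3 shares the same pattern of methoxy groups but has a different core; the difference between the two cores is not broken down here. Its value in this assay lies within the scatter of that of compound 1, so no order between them can be claimed.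

Compound 4 `COc1ccc(-c2ccsc2-c2cc(OC)c(OC)c(OC)c2)cc1[N+](=O)[O-]` is not yet measured. It differs from compound 3 by nitro in place of hydrogen on an aromatic carbon, the same change as that from compound 1 to compound 2. Since the earlier nitro step gave a 3.5-fold higher number from compound 1 to compound 2 (0.54 log units; beyond the scatter), a step of similar size is expected for a 3.0-fold higher number from compound 3 to compound 4 (0.47 log units; beyond the scatter) in this assay. Compound 4 is accordingly expected to give about 22000 nM, with a likely range from 9000 nM to 60000 nM.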

Compound 4, half-maximal inhibitory concentration: 21000 nM
Compound 4: middle estimate off by 1.0-fold (0.02 log units), on the high side; measured number inside the range.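

In this assay, nitro in place of hydrogen on an aromatic carbon gave a 2.8-fold higher number from compound 3 to compound 4 (0.45 log units; beyond the scatter). Set beside the earlier step, the change carried from one core to the other with no difference that can be told apart: the same change on two cores in this assay, a 3.5-fold higher number (0.54 log units; beyond the scatter) from compound 1 to compound 2 and a 2.8-fold higher number (0.45 log units; beyond the scatter) from compound 3 to compound 4, 1.2-fold (0.09 log units) apart, within the scatter of two such steps This shows a step of matching direction and size on these two cores, but it rests on two pairs and one place, ortho to a methoxy group, so it does not show that the change would carry to other cores or explain the rise in the number.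

The compounds shown leave open whether an amine in that same place would shift the number as nitro does. They also leave open whether an amide in place of the carboxylic acid of compound 1 would alter the step.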